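A Urea Aryl Swap on the Shared Core

The source may hold more compounds than are shown below. What is called first, only, known or untested is meant among the compounds shown, and "the series" means these compounds.

Compound 1 `O=C(Nc1cccc(-n2cc(-c3ccncc3)c(-c3ccc(Cl)c(O)c3)n2)c1)Nc1ccc(Cl)c(Cl)c1` carries the highest number of the two measured in a functional assay on A498 cells (Homo sapiens) for inhibition, read by sulforhodamine B assay, with a stated time of 48 h (on this read-out higher numbers stand for weaker inhibition of growth and lower numbers for stronger inhibition of growth), giving 3170 nM; compound 2 `COc1cc(-c2nn(-c3cccc(NC(=O)c4ccccc4)c3)cc2-c2ccncc2)ccc1Cl` gives 3140 nM in this assay, a value within the scatter of compound 1, so the two cannot be ordered. Compound 3 `O=C(Nc1cccc(-n2cc(-c3ccncc3)c(-c3ccc(Cl)c(O)c3)n2)c1)Nc1cccc(C(F)(F)F)c1` keeps the core of compound 1 and differs in one place: 3-(trifluoromethyl)phenyl in place of 3,4-dichlorophenyl on an amide-type nitrogen. Among the measured compounds shown here, no measured pair shows the effect of this change, so a step near the scatter is expected, if anything toward a higher number. Compound 3 is expected to give 4000 nM, between 1500 nM and 10000 nM, which means an estimated step of a 1.3-fold higher number from compound 1 to compound 3 (0.10 log units; within the scatter).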

Compound 3, concentration for total growth inhibition: > 32500 nM
Compound 3: only a limit was reported; the forecaster's own chance of this, stated with the estimate: 5%; at least 8.1-fold (0.90 log units) between middle value and limit.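

At this place, on an amide-type nitrogen, the aryl group cannot be exchanged freely: 3-(trifluoromethyl)phenyl in place of 3,4-dichlorophenyl brings an at least 10-fold higher number from compound 1 to compound 3 (1.01 log units; beyond the scatter) in this assay. The value of compound 3 is a limit and not a number: the limit of > 32500 nM in this assay, at which 1 of the 3 values shown sits. Among the compounds shown here, compounds 1 and 2 differ in more than one place, so only this pair shows that the read-out responds strongly to the group on this nitrogen.

The compounds shown leave open how a 3-chlorophenyl or a 4-chlorophenyl group on this nitrogen would compare with compound 1.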